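Swapping Methoxy for Trifluoromethyl in Compound 1

The source may hold more compounds than are shown below. What is called first, only, known or untested is meant among the compounds shown, and "the series" means these compounds.

Among the compounds with values here, compound 1 `COc1cccc(C(=O)/C=C/c2ccccc2)c1` gives 14800 nM in an ADME assay on MSTO-211H cells (Homo sapiens) for inhibition, read by trypan blue exclusion, with a stated time of 72 h (a higher number here means a weaker inhibitor of growth, a lower number a stronger inhibitor of growth), the highest of the two numbers measured so far. Compound 2 `O=C(/C=C/c1cccc([N+](=O)[O-])c1)c1ccccc1` gives 5100 nM in this assay, a lower number that lies beyond the scatter. Compound 3 `O=C(/C=C/c1ccccc1)c1cccc(C(F)(F)F)c1` has not yet been measured; it differs from compound 1 by trifluoromethyl in place of methoxy on an aromatic carbon. Within the data shown here, no pair of measured compounds shows this change, so the expectation here is the step of a 1.9-fold lower number from compound 1 to compound 3 (0.27 log units; within the scatter), a modest move toward a lower number, at the edge of the scatter. Compound 3 is therefore estimated at 8000 nM, with a range from 3000 nM to 25000 nM.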

Compound 3, concentration for 50% growth inhibition: > 20000 nM
Compound 3: only a limit was reported; the forecaster's own chance of this, stated with the estimate: 5%; at least 2.5-fold (0.39 log units) between middle value and limit.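

In this assay, the reading for compound 3 is a limit and not a number: the limit of > 20000 nM in this assay, at which 1 of the 3 values shown sits.

On the aromatic carbon that carries methoxy in compound 1, trifluoromethyl in its place gives an at least 1.3-fold higher number from compound 1 to compound 3 (0.13 log units; that floor lies within the scatter). Within the data shown here, this is the first step read at this position, and it shows no move toward a lower number, although the true size of any rise remains unknown.

As far as these compounds go, what an amine or a hydroxyl group in place of methoxy would give in this assay stays open. So does how far the true value of compound 3 lies beyond its limit.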